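Swapping a Fluorophenyl for a Hydroxyphenyl in Compound 3

A few compounds are considered here, and "the series" means these few. Any claim that something is new, unique, unknown or untested is made for them only; others in the source may bear on it.

Compound 1 `COc1cc(/C=C2\CCC/C(=C\c3ccccc3Br)C2=O)cc(OC)c1OC` and compound 2 `COc1cc(/C=C2\CCC/C(=C\c3ccccc3F)C2=O)cc(OC)c1OC` share one core and differ at a single point. In a functional assay on SW-620 cells (Homo sapiens) for antiproliferative activity, read by MTT assay, with a stated time of 72 h (a lower number here means a stronger inhibitor, a higher number a weaker inhibitor), compound 1 gives 3300 nM, and in this assay compound 2 gives 2100 nM. The step of a 1.6-fold lower number from compound 1 to compound 2 (0.20 log units; within the scatter) is the only one measured so far. Compound 2 therefore holds the lowest of the two numbers, yet its gap to compound 1 lies within the scatter, so no order between them can be claimed. Compound 3 `COc1cc(/C=C2\CCC/C(=C\c3cccc(O)c3)C2=O)cc(OC)c1OC` carries 3-hydroxyphenyl in place of 2-fluorophenyl on a double-bonded chain carbon bound to a double-bonded ring carbon. Going by the values given here, no measured step covers a hydroxyl entering or a fluorine leaving; the one step, a 1.6-fold lower number from compound 1 to compound 2 (0.20 log units; within the scatter), exchanged one halogen for another and stayed within the scatter. It gives no direction, so the expected step is a 1.2-fold higher number from compound 2 to compound 3 (0.08 log units; within the scatter), none beyond the scatter. Compound 3 is expected to give about 2500 nM in this assay, with a range from 700 nM to 9000 nM.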

Compound 3, half-maximal inhibitory concentration: > 10000 nM
Compound 3: no number, only a limit; the forecaster's own chance of this, stated with the estimate: 5%; at least 4.0-fold (0.60 log units) between middle value and limit.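

Until this point the position had seen only one halogen exchanged for another, with no change that could be read beyond the scatter. Going by these compounds alone, the step to 3-hydroxyphenyl is the first at this place on the double-bonded chain carbon to clear the scatter, and it clears it from both halogen compounds, with an at least 4.7-fold higher number from compound 2 to compound 3 (0.67 log units; beyond the scatter) and an at least 3.0-fold higher number from compound 1 to compound 3 (0.48 log units; beyond the scatter). So this position does not tolerate every aryl group equally, and compound 3 gives only a limit of this assay rather than a number: the limit of > 10000 nM in this assay, at which 1 of the 3 values shown sits.

As far as these compounds go, because the hydroxyl and its place on the ring change together here, the steps do not separate the two, and whether a 2-hydroxyphenyl or a 3-fluorophenyl would act like 3-hydroxyphenyl stays open. From the compounds shown here alone, how an amine or a carboxylic acid on the same ring would read in this assay also stays open.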